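Aromatising the urea-side bicycle of compound 2

The source may hold more compounds than are shown below. What is called first, only, known or untested is meant among the compounds shown, and "the series" means these compounds.

Compound 2 `CN(C)C1(Cc2ccccc2)CCN(c2cc(C(F)(F)F)ccc2CNC(=O)Nc2cccc3c2CC(O)CC3)CC1` gives 10.1 nM in an assay on CHO cells for antagonist activity at transient receptor potential cation channel subfamily V member 1 (Homo sapiens), read by scintillation counting, with a stated time of 5 min, in the presence of a further agent that is not named here; on this read-out lower numbers stand for an effect already at smaller amounts and higher numbers for an effect only at larger amounts of compound; that is the lowest of the two numbers, and compound 1 `CN(C)C1(Cc2ccccc2)CCN(c2cc(C(F)(F)F)ccc2CNC(=O)Nc2ccc(CNS(C)(=O)=O)c(F)c2)CC1` stands nearest with 25 nM, a gap the data place beyond the scatter. Compound 3 `CN(C)C1(Cc2ccccc2)CCN(c2cc(C(F)(F)F)ccc2CNC(=O)Nc2cccc3c(=O)[nH]ccc23)CC1` keeps the shared core and differs from compound 2 only in a group of 11 heavy atoms (9 carbon, 1 nitrogen, 1 oxygen; one six-membered aromatic ring of carbon only, one six-membered aromatic ring with 1 hetero atom) in place of a group of 11 heavy atoms (10 carbon, 1 oxygen; one six-membered non-aromatic ring of carbon only, one six-membered aromatic ring of carbon only), on an amide-type nitrogen. The leaving 3-hydroxy-1,2,3,4-tetrahydronaphthalen-5-yl and the entering group each carry one hydrogen-bond donor and one hydrogen-bond acceptor, so the count of polar handles on the urea nitrogen is unchanged, while one six-membered non-aromatic ring gives way to one six-membered aromatic ring with 1 hetero atom. Within the data shown here, no pair of measured compounds shows this kind of change, so a small step in either direction is the plain expectation, a 1.3-fold higher number from compound 2 to compound 3 (0.11 log units; within the scatter), and compound 3 is estimated at 13 nM in this assay, within 4 nM to 40 nM.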

Compound 3, half-maximal effective concentration: "not active" (no number reported)
No number was reported for compound 3; there is nothing to compare the estimate with.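

Among these compounds, compound 3 carries no number in this assay and no step from compound 2 can be read. Nothing available here bears on this result. The compounds shown leave open which part of the exchange of the 3-hydroxy-1,2,3,4-tetrahydronaphthalen-5-yl group governs the read-out.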